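Moving a bromine around the phenoxy ring

A few compounds are considered here, and "the series" means these few. Any claim that something is new, unique, unknown or untested is made for them only; others in the source may bear on it.

Compound 1, `Cc1nn(C)c(Oc2ccccc2F)c1/C=N\CCCCCCOc1cc2oc(=O)cc(C)c2cc1Cl`: in a functional assay on HepG2 cells (Homo sapiens) for antiproliferative activity, read by MTT assay, with a stated time of 72 h (a higher number here means a weaker inhibitor, a lower number a stronger inhibitor), compound 1 gives > 25000 nM, which is a limit of the assay and not a number.
Compound 2, `Cc1nn(C)c(Oc2ccccc2Br)c1/C=N\CCCCCCOc1cc2oc(=O)cc(C)c2cc1Cl`: in this assay compound 2 gives 24200 nM.
Compound 3, `Cc1nn(C)c(Oc2cccc(Br)c2)c1/C=N\CCCCCCOc1cc2oc(=O)cc(C)c2cc1Cl`: not yet measured in this assay.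

Compound 2 thus holds the only number shown; the one other value is a limit, (the limit of > 25000 nM in this assay, at which 1 of the 2 values shown sits). Within the data shown here, the single measured step, an at least 1.0-fold lower number from compound 1 to compound 2 (0.01 log units; that floor lies within the scatter), lies within the scatter. Compound 3 differs from compound 2 by 3-bromophenyl in place of 2-bromophenyl on an oxygen on an aromatic ring. No measured step moves a group to another position on that ring; the only step shown swaps one halogen for another at the same position and changes nothing beyond the scatter. The expected step is therefore none beyond the scatter: compound 3 is estimated at 24000 nM, within 10000 nM to 60000 nM, an expected step of a 1.0-fold lower number from compound 2 to compound 3 (0.00 log units; within the scatter). The limit of > 25000 nM in this assay, at which 1 of the 2 values shown sits, stands close to this estimate, so compound 3 may also come back as a limit only.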

Compound 3, half-maximal inhibitory concentration: 6830 nM
Compound 3: the middle estimate sits 3.5-fold (0.55 log units) above what was measured; measured number below the stated range.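

In this assay, among these compounds, the place of the bromine on the ring matters, whereas the one halogen swap seen earlier changed nothing beyond the scatter. Among the compounds shown here, with the same atoms joined differently, 3-bromophenyl in place of 2-bromophenyl gives a 3.5-fold lower number from compound 2 to compound 3 (0.55 log units; beyond the scatter), the first clear change in this small series. Against the fluoro compound, the step reads an at least 3.6-fold lower number from compound 1 to compound 3 (0.56 log units; beyond the scatter), which gives only a floor for the true gap. Compound 1 carries a limit of the assay and not a number: the limit of > 25000 nM in this assay, at which 1 of the 3 values shown sits.

Going by these compounds, what stays open is whether the bromine itself is needed on this ring, or whether a chlorine, a methoxy group or a nitrile at the same place would serve as well. On these data alone, whether a shorter chain in the shared core would shift the number also remains unknown.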